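Replacing a nitrile by a nitro group on the benzyl ether

The compounds below may be only part of what the source reports. "The series", "measured", "known", "first", "only" and "open" are said of these compounds alone.

Measured compounds:
compound 1 `N#Cc1ccccc1COc1c(-c2ccccc2)oc2cc(O)cc(O)c2c1=O`; compound 2 `COc1cccc(COc2c(-c3ccccc3)oc3cc(O)cc(O)c3c2=O)c1`; compound 3 `O=c1c(OCc2ccc(Br)cc2)c(-c2ccccc2)oc2cc(O)cc(O)c12`

In an ADME assay on Huh-5-2 cells (Homo sapiens) for cytotoxicity, read by WST assay, with a stated time of 3 days (on this read-out higher numbers stand for lower toxicity in this test and lower numbers for higher toxicity in this test), compound 2 gives 28000 nM and compound 3 gives 2000 nM. For compound 1 the result in this assay is only a limit of the assay, > 100000 nM. So compound 1 stands at the limit (the limit of > 100000 nM in this assay, at which 1 of the 3 values shown sits), and only a range, not a number, is known for it.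

Compound 4 `O=c1c(OCc2ccc([N+](=O)[O-])cc2)c(-c2ccccc2)oc2cc(O)cc(O)c12` differs from compound 1 in one place: 4-nitrophenyl in place of 2-cyanophenyl on a saturated chain carbon bound to an oxygen on an aromatic ring.

Two measured steps leave the same position of compound 1. The step of an at least 3.5-fold lower number from compound 1 to compound 2 (0.55 log units; beyond the scatter) is at least modest; the step of an at least 50-fold lower number from compound 1 to compound 3 (1.69 log units; beyond the scatter) is large, and the step of a 14-fold lower number from compound 2 to compound 3 (1.15 log units; beyond the scatter) is also large. Both steps that start from compound 1 move downward in this assay. A downward step of at least modest size is therefore expected for compound 4, and the step of an at least 5.0-fold lower number from compound 1 to compound 4 (0.69 log units; beyond the scatter) is the estimate. For compound 4 the expected value in this assay is 20000 nM, with a range of 4000 nM to 100000 nM.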

Compound 4, half-maximal cytotoxic concentration: 40000 nM
Compound 4: the middle estimate sits 2.0-fold (0.30 log units) below what was measured, and the stated range covers the measured number.
By their numbers in this assay, from the lowest: compound 3; then compounds 2 and 4 (each within the scatter of the next). At a limit, above all of these: compound 1.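

In this assay, 4-nitrophenyl in place of 2-cyanophenyl gives an at least 2.5-fold lower number from compound 1 to compound 4 (0.39 log units; beyond the scatter), so this change on the saturated chain carbon also brings a measurable number. Compound 1 stands only at a limit, so that step gives a bound and not a size: the limit of > 100000 nM in this assay, at which 1 of the 4 values shown sits. Nitro in place of bromo on an aromatic carbon gives a 20-fold higher number from compound 3 to compound 4 (1.30 log units; beyond the scatter), while the other new comparison gives a 1.4-fold higher number from compound 2 to compound 4 (0.15 log units; within the scatter), so compound 3 alone stands apart from the others with a measured number.

Going by these compounds, what a 4-cyanophenyl group would give in this assay remains open, and with it whether the nitrile itself or its place on the ring goes with the limit seen for compound 1. Also open, on these data alone, is how an amine, a carboxylic acid or a longer chain at this position would behave.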